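The source may hold more compounds than are shown below. What is called first, only, known or untested is meant among the compounds shown, and "the series" means these compounds.

Compound 2 `CC(C)(C)c1cc(Sc2nnc(O)o2)cc(C(C)(C)C)c1O` gives 1100 nM in an assay on RBL-1 cells for inhibition of Polyunsaturated fatty acid 5-lipoxygenase (Rattus norvegicus) (on this read-out higher numbers stand for weaker inhibition and lower numbers for stronger inhibition), and stands level with compound 1 `CC(C)(C)c1cc(Sc2nnc(S)s2)cc(C(C)(C)C)c1O`, which gives 1100 nM in this assay. For the measured compounds named here, the only measured step, no change at the digits printed from compound 1 to compound 2 (within the scatter), exchanged the whole heterocycle together with its substituent and left the read-out where it was. Compound 3 `CC(C)(C)c1cc(Sc2nnc(S)o2)cc(C(C)(C)C)c1O` keeps the ring of compound 2 and differs at a single point: sulfanyl in place of hydroxy on an aromatic carbon. This is a narrower change than that step, so no movement beyond the scatter is expected in this assay in either direction. Compound 3 is expected at 1100 nM, within 500 nM to 2500 nM. The expected step is no change at the digits printed from compound 2 to compound 3 (within the scatter).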

Compound 3, half-maximal inhibitory concentration: 2000 nM
Beside the measured number, compound 3's estimate is 1.8-fold (0.26 log units) below it; measured number inside the range.
By their numbers in this assay, from the lowest: compounds 1, 2 and 3 (each within the scatter of the next).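

In this assay, the oxygen-to-sulfur exchange on the aromatic carbon alone, sulfanyl in place of hydroxy, gives a 1.8-fold higher number from compound 2 to compound 3 (0.26 log units; within the scatter). The ring exchange alone, 5-sulfanyl-1,3,4-oxadiazol-2-yl in place of 5-sulfanyl-1,3,4-thiadiazol-2-yl on a sulfur, gives a 1.8-fold higher number from compound 1 to compound 3 (0.26 log units; within the scatter), so each single exchange, like the earlier combined one, stays within the scatter. Nothing available accounts for this result. Still open, going by these compounds, is whether this aromatic carbon keeps the read-out with an amine, a carboxylic acid or a longer chain such as methylsulfanyl in place of sulfanyl.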